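Clearance Expected After a Halogen Swap on the Phenyl Ring

The compounds below may be only part of what the source reports. "The series", "measured", "known", "first", "only" and "open" are said of these compounds alone.

Measured in an ADME assay on liver (Mesocricetus auratus) for metabolic stability, using microsomes; on this read-out lower numbers stand for slow clearance and higher numbers for fast clearance:
Compound 1 `O=C(Nc1cc(-c2ccccn2)n[nH]1)N1CCC(c2cccc(F)c2)CC1`: 207 mL.min-1.g-1
Compound 2 `O=C(Nc1cc(-c2ccccn2)n[nH]1)N1CCN(c2ccc(F)cc2)CC1`: 46.5 mL.min-1.g-1

Compound 1, at 207 mL.min-1.g-1, stands highest of the two, and compound 2, at 46.5 mL.min-1.g-1, lies lower by more than the usual scatter. Compound 3 `O=C(Nc1cc(-c2ccccn2)n[nH]1)N1CCC(c2ccc(Cl)cc2)CC1` has not yet been measured. It departs from compound 1 as follows: 4-chlorophenyl in place of 3-fluorophenyl on a saturated ring carbon. Among the measured compounds shown here, no measured pair shows a change of this kind. No step beyond the scatter is therefore expected in this assay, and the estimated step is a 1.1-fold lower number from compound 1 to compound 3 (0.04 log units; within the scatter). The estimate for compound 3 is 190 mL.min-1.g-1, with an expected range of 85 mL.min-1.g-1 to 420 mL.min-1.g-1.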

Compound 3, intrinsic clearance in microsomes: 43.8 mL.min-1.g-1
Beside the measured number, compound 3's estimate is 4.3-fold (0.64 log units) above it; the measured number lies below the stated range.
By their numbers in this assay, from the lowest: compounds 3 and 2 (each within the scatter of the next); then compound 1.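

In this assay, 4-chlorophenyl in place of 3-fluorophenyl on a saturated ring carbon gives a 4.7-fold lower number from compound 1 to compound 3 (0.67 log units; beyond the scatter), showing that the phenyl group at this position can shift clearance beyond the scatter. The two groups differ in both the halogen and where it sits, so the step cannot be assigned to either alone. Nothing available explains the step. The compounds shown leave open whether 4-fluorophenyl or 3-chlorophenyl on this carbon would sit nearer compound 1 or compound 3, and how an amine on the phenyl ring would behave.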